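The compounds below may be only part of what the source reports. "The series", "measured", "known", "first", "only" and "open" are said of these compounds alone.

Of the compounds shown here, three built on one shared core have been tested in a functional assay on KG-1 cells (Homo sapiens) for cytotoxicity, read by luminescence and CellTiter-Glo, with a stated time of 3 days; a lower number here means a stronger inhibitor, a higher number a weaker inhibitor. Compound 1, `O=C(Nc1ccc(C(F)(F)F)cc1)c1cc(Br)ccc1O`, gives 610 nM. Compound 2, `O=C(Nc1ccc(OC(F)(F)F)cc1)c1cc(F)ccc1O`, gives 780 nM in this assay. Compound 3, `N#Cc1ccc(NC(=O)c2cc(Br)ccc2O)cc1`, gives 1290 nM in this assay, the highest of the three numbers: its gap to compound 2 lies within the scatter, while the step of a 2.1-fold higher number from compound 1 to compound 3 (0.33 log units; beyond the scatter) comes from cyano in place of trifluoromethyl on an aromatic carbon.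

Compound 4, `N#Cc1ccc(NC(=O)c2cc(Cl)ccc2O)cc1`, has not yet been measured. It differs from compound 3 in one place: chloro in place of bromo on an aromatic carbon. Going by the values given here, no measured pair isolates this exchange of one halogen for another on the core. Among the compounds with values here, the only measured step concerns a different group on the other ring, and compounds 1 and 2 differ from each other in two places at once, so their two values cannot be split into separate contributions. With nothing directly bearing on chloro in place of bromo on an aromatic carbon, the expected step of a 1.2-fold higher number from compound 3 to compound 4 (0.07 log units; within the scatter) is small, most likely within the scatter, and its direction is uncertain. The estimate for compound 4 in this assay is therefore 1500 nM, with a range from 700 nM to 3200 nM.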

Compound 4, half-maximal inhibitory concentration: 1860 nM
Compound 4: the middle estimate sits 1.2-fold (0.09 log units) below what was measured, and the stated range covers the measured number.
By their numbers in this assay, from the lowest: compounds 1, 2, 3 and 4 (each within the scatter of the next, the first and the last beyond it).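

In this assay, placing chloro instead of bromo on this aromatic carbon, para to a hydroxy group and meta to a large group, gives a 1.4-fold higher number from compound 3 to compound 4 (0.16 log units; within the scatter), so this pair does not separate the two halogens. Going by these compounds alone, it is the first measured pair to isolate a change at this position, which compounds 1 and 2 could not do, since they differ from each other in two places at once. Within this pair, with cyano on the other ring, the choice of bromo or chloro therefore makes no difference that can be told from the usual variation between repeated measurements, and no separate measurement is available to explain the size of this step.

The compounds shown leave open whether the same exchange would give a similar result with trifluoromethyl or trifluoromethoxy on the other ring, as a single pair cannot establish a general rule. They also leave open how a group of a different kind at this position, such as an amine, a methoxy group or a carboxylic acid, would compare with bromo and chloro.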